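Swapping an Isopropyl Ester for a Benzyl Ester

The compounds below may be only part of what the source reports. "The series", "measured", "known", "first", "only" and "open" are said of these compounds alone.

Compound 1 `CC(/C=C/CC(C)CCCC(C)C)=C\C(=O)OC(C)C` is a diene ester with a branched alkyl chain. Among the compounds with values here, in a physicochemical assay for lipophilicity (a lower number here means a more polar compound, a higher number a more lipophilic compound), compound 1 gives 7.15, the higher of the two numbers measured so far. Its partner compound 2 `C=CCOC(=O)/C=C(C)/C=C/CC(C)CCCC(C)C` carries an allyl group on the same oxygen, and in this assay compound 2 gives 6.73; the step of a number 0.42 log units lower from compound 1 to compound 2 (beyond the scatter) is modest but beyond the scatter. Compound 3 `CC(/C=C/CC(C)CCCC(C)C)=C\C(=O)OCc1ccccc1` has not yet been measured. It differs from compound 1 in one place: benzyl in place of isopropyl on an oxygen next to a carbonyl group. Within the data shown here, the only measured step at this position, from compound 1 to compound 2, shows that the group on this oxygen does move the partition coefficient. Since benzyl brings in a six-membered aromatic ring where isopropyl leaves, compound 3 is expected to sit above compound 1, with an estimated step of a number 0.55 log units higher from compound 1 to compound 3 (beyond the scatter). The estimate for compound 3 in this assay is 7.7, with a range from 7.25 to 8.15.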

Compound 3, partition coefficient: 7.87
Estimate against measurement, compound 3: 0.17 log units below, and the stated range covers the measured number.
By their numbers in this assay, from the lowest: compound 2; then compound 1; then compound 3.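

In this assay the group on this oxygen can now be seen to move the number in both directions from isopropyl: benzyl gives a number 0.72 log units higher from compound 1 to compound 3 (beyond the scatter) while allyl lay on the lower side. The widest gap so far is a number 1.14 log units higher from compound 2 to compound 3 (beyond the scatter) and comes from phenyl in place of vinyl on a saturated chain carbon bound to an oxygen next to a carbonyl group, so the end of this small group matters to the read-out. No separate measurement here accounts for either step.

Benzyl differs from isopropyl in both its carbon count and its aromatic ring, and these compounds cannot separate the two; a cyclohexylmethyl group on the same oxygen would speak to that. On these data alone, whether the order holds for a longer chain, such as n-butyl, also remains open.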